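Amide variation in the series: cytotoxicity notes

The source may report more compounds than this note shows. Statements on the series, on what has been measured and on what is new or still open speak of the compounds shown alone.

Measured so far:
compound 1 `CCCN(C(=O)CN(C)C(=O)c1ccc(S(C)(=O)=O)c([N+](=O)[O-])c1)c1ccccc1` — > 27000 nM
compound 2 `CN(Cc1cccc(F)c1)C(=O)CN(C)C(=O)c1ccc(S(C)(=O)=O)c([N+](=O)[O-])c1` — > 27000 nM

In an ADME assay on HepG2 cells (Homo sapiens) for cytotoxicity, read by CellTiter-Glo and ATP content, with a stated time of 72 h (on this read-out lower numbers stand for an effect already at smaller amounts and higher numbers for an effect only at larger amounts of compound), compound 1 gives > 27000 nM, which is a limit of the assay and not a number. In this assay compound 2 gives > 27000 nM, likewise a limit and not a number. Both measured values share (the limit of > 27000 nM in this assay, at which 2 of the 2 values shown sit). Within the data shown here, the single step at the amide position, a step that the two limits leave unreadable from compound 1 to compound 2, is therefore unreadable in size, and no sized step exists in this assay. Compound 2 thus stands only at a limit, on the same footing as compound 1, with no number that would set it apart.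

Compound 3 `CC1CCN(C(=O)CN(C)C(=O)c2ccc(S(C)(=O)=O)c([N+](=O)[O-])c2)CC1` carries 4-methylpiperidin-1-yl in place of (3-fluorobenzyl)(methyl)amino on a carbonyl carbon. Among the measured compounds shown here, the one measured step that bears on this position is a step that the two limits leave unreadable from compound 1 to compound 2, and it gives no size, so no step beyond the scatter in either direction can be predicted; the step from compound 2 to compound 3 is expected to be a step that the limit leaves unreadable from compound 2 to compound 3, that is, none that the assay would resolve. Compound 3 is expected to give 40000 nM in this assay, with an estimated range from 20000 nM to 120000 nM, and the result will most probably again be reported only as a limit.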

Compound 3, half-maximal effective concentration: > 27000 nM
Compound 3: a limit, no number (the forecaster's own chance of this, stated with the estimate: 85%); the middle value lies beyond the limit too.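

No new step can be read in this assay among compound 1, compound 2 and compound 3, as all three values are limits and not numbers: the limit of > 27000 nM in this assay, at which 3 of the 3 values shown sit. The compounds shown leave open where any of the three would reach a numerical half-maximal effective concentration, and whether the groups on the carbonyl carbon differ at all in this read-out.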